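Swapping a Small Fluoro for a Large Cyclohexyl Group

The source may hold more compounds than are shown below. What is called first, only, known or untested is meant among the compounds shown, and "the series" means these compounds.

compound 1 `CC(C(=O)NCc1ccc(C(F)(F)F)cc1N1CCC(C(F)(F)F)CC1)c1ccc(NS(C)(=O)=O)c(F)c1`: 0.4 nM
compound 2 `CC(C(=O)NCc1ccc(C(F)(F)F)cc1F)c1ccc(NS(C)(=O)=O)c(F)c1`: 68.7 nM

Both were tested in an assay on CHO cells for antagonist activity at transient receptor potential cation channel subfamily V member 1 (Homo sapiens), read by FLIPR; a higher number here means a weaker inhibitor, a lower number a stronger inhibitor. Of these two numbers, compound 2 gives the highest. Among the measured compounds shown here, the one measured step that bears on the new change is a 170-fold higher number from compound 1 to compound 2 (2.23 log units; beyond the scatter), where a small fluoro took the place of a large ring. Compound 3 `CC(C(=O)NCc1ccc(C(F)(F)F)cc1C1CCCCC1)c1ccc(NS(C)(=O)=O)c(F)c1` goes the other way: cyclohexyl in place of fluoro on an aromatic carbon. Because a large group on the same aromatic carbon in compound 1 went with 0.4 nM, a large fall in this assay is expected, though the new ring differs from that of compound 1. Compound 3 is therefore estimated at 2 nM, within 0.4 nM to 12 nM, a step of a 34-fold lower number from compound 2 to compound 3 (1.54 log units; beyond the scatter).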

Compound 3, inhibition constant: 0.6 nM
Estimate against measurement, compound 3: 3.3-fold (0.52 log units) above, and the stated range covers the measured number.
By their numbers in this assay, from the lowest: compounds 1 and 3 (each within the scatter of the next); then compound 2.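

In this assay, cyclohexyl in place of fluoro gives a 110-fold lower number from compound 2 to compound 3 (2.06 log units; beyond the scatter), so a large gain at this aromatic carbon does not depend on the piperidine ring of compound 1. Set against that ring, cyclohexyl gives a 1.5-fold higher number from compound 1 to compound 3 (0.18 log units; within the scatter), so the two large groups cannot be told apart here, even though cyclohexyl is carbon only. Nothing available gives a reason for either step. From the compounds shown here alone, whether a cyclopentyl ring, a phenyl ring or an open tert-butyl group on this carbon would perform like cyclohexyl remains open.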